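Oxanyl to pyridyl on the carbonyl of compound 3

The source may report more compounds than this note shows. Statements on the series, on what has been measured and on what is new or still open speak of the compounds shown alone.

Measured so far:
compound 1 `O=C(C1CCN(c2ccncn2)CC1)N1N=CC[C@H]1c1ccccc1` — 3.2
compound 2 `CC(C)(C)C(=O)N1N=CCC1c1cc[nH]n1` — 2.7
compound 3 `O=C(C1CCOCC1)N1N=CCC1c1ccccc1` — 3.1

In a physicochemical assay for lipophilicity, read by HPLC, measured as chromatographic lipophilicity, at pH 7.4 (a higher number here means a more lipophilic compound, a lower number a more polar compound), compound 3 gives 3.1. Compound 1 gives 3.2 in this assay, and the gap between compound 1 and compound 3 is within the scatter, so the two cannot be told apart. Compound 2 gives 2.7 in this assay, a number beyond the scatter below compound 3; compound 2 differs from compound 3 in more than one place, so no single step can be read from that pair.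

Compound 4 `O=C(c1ccncc1)N1N=CCC1c1ccccc1` is not yet measured. It differs from compound 3 in one place: pyridin-4-yl in place of oxan-4-yl on a carbonyl carbon. Both the leaving group and the entering group carry one hetero atom in a six-membered ring and one hydrogen-bond acceptor; the ring changes from non-aromatic to aromatic. Among the compounds with values here, no measured pair shows this change, so the step must be guessed.

The expectation is a small step, a number 0.10 log units higher from compound 3 to compound 4 (within the scatter), not beyond the scatter in either direction. Compound 4 is therefore estimated at 3.2 in this assay, with a range from 2.7 to 3.7.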

Compound 4, distribution coefficient: 2.7
Estimate against measurement, compound 4: 0.50 log units above; the range from low to high includes it.
By their numbers in this assay, from the lowest: compounds 2 and 4 (each within the scatter of the next); then compounds 3 and 1 (each within the scatter of the next).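

In this assay, within the data shown here, pyridin-4-yl in place of oxan-4-yl on a carbonyl carbon whose other neighbour is an amide-type nitrogen in a ring gives a number 0.40 log units lower from compound 3 to compound 4 (beyond the scatter), the only step so far that can be read at a single place. The leaving and entering groups have the same counts of heavy atoms, hetero atoms, hydrogen-bond donors and hydrogen-bond acceptors, and neither carries a net charge, so a matching count does not ensure a matching number at this position; what differs is an aromatic ring for a non-aromatic one and nitrogen for oxygen, and this single step cannot separate the two. Nothing available bears on why the number moves.

Cyclohexyl or phenyl on the same carbonyl carbon would be needed to separate the ring change from the change of hetero atom, and pyridin-3-yl would show whether the place of the ring nitrogen matters. Going by these compounds, whether the step holds on another core also stays open, since it rests on this one pair.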